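Exchanging One Substituted Phenyl for Another

A few compounds are considered here, and "the series" means these few. Any claim that something is new, unique, unknown or untested is made for them only; others in the source may bear on it.

In a functional assay on A2780 cells (Homo sapiens) for antiproliferative activity, read by fluorescence, with a stated time of 72 h (a higher number here means a weaker inhibitor, a lower number a stronger inhibitor), compound 1 `CN1CCC(C(=O)N2Cc3c(NC(=O)C4CC4)n[nH]c3C2(C)C)CC1` gives 1420 nM and compound 2 `CN1CCC(C(=O)N2Cc3c(NC(=O)c4ccc5ccccc5c4)n[nH]c3C2(C)C)CC1` gives 270 nM while compound 3 `CN1CCC(C(=O)N2Cc3c(NC(=O)c4cc(F)cc(F)c4)n[nH]c3C2(C)C)CC1` gives 130 nM as the lowest of the three. Compound 4 `CN1CCC(C(=O)N2Cc3c(NC(=O)c4ccc(Cl)cc4)n[nH]c3C2(C)C)CC1` is still unmeasured and carries 4-chlorophenyl in place of 3,5-difluorophenyl on a carbonyl carbon. Replacing cyclopropyl with an aromatic group gave larger steps (a 5.3-fold lower number from compound 1 to compound 2 (0.72 log units; beyond the scatter); an 11-fold lower number from compound 1 to compound 3 (1.04 log units; beyond the scatter)). The closest guide is the exchange of one aromatic group for another, which gave only a modest step (a 2.1-fold lower number from compound 2 to compound 3 (0.32 log units; beyond the scatter)). For this similar exchange in this assay the expected outcome is no step beyond the scatter (a 1.5-fold higher number from compound 3 to compound 4 (0.19 log units; within the scatter)). Compound 4 is expected at 200 nM within an estimated range of 90 nM to 450 nM in this assay.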

Compound 4, half-maximal inhibitory concentration: 120 nM
For compound 4 the middle estimate is 1.7-fold (0.22 log units) above the measured one; the measured number falls inside the stated range.
By their numbers in this assay, from the lowest: compounds 4 and 3 (each within the scatter of the next); then compound 2; then compound 1.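

In this assay, the exchange at this carbonyl carbon gives no step beyond the scatter (a 1.1-fold lower number from compound 3 to compound 4 (0.03 log units; within the scatter)), so two differently substituted phenyl groups cannot be told apart here. The 4-chlorophenyl group also stands clear of the other two groups, with a 2.3-fold lower number from compound 2 to compound 4 (0.35 log units; beyond the scatter) and a 12-fold lower number from compound 1 to compound 4 (1.07 log units; beyond the scatter). No measurement at hand explains why these two phenyl groups match.

Still open, from the compounds shown here alone, is whether unsubstituted phenyl would match them. A phenyl ring carrying an amine or a carboxylic acid is also untested among these compounds.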